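The source may report more compounds than this note shows. Statements on the series, on what has been measured and on what is new or still open speak of the compounds shown alone.

- compound 1 `COc1ccc(/C=C/C2(C)C=CC(=O)O2)cc1OC`: 193000 nM
- compound 2 `CC1(/C=C/c2ccc(O)cc2)C=CC(=O)O1`: 107000 nM
- compound 3 `COc1ccc(/C=C/C2(C)C=CC(=O)O2)cc1`: not yet measured

In a functional assay on U-251 cells (Homo sapiens) for inhibition, read by sulforhodamine B assay, with a stated time of 48 h (a lower number here means a stronger inhibitor of growth, a higher number a weaker inhibitor of growth), compound 2 gives 107000 nM. It holds the lowest number shown, but compound 1 at 193000 nM lies within the scatter of it, so the two cannot be ranked. Compound 3 differs from compound 2 at one place, with methyl in place of hydrogen on an oxygen on an aromatic ring, hydroxy to methoxy: methyl in place of hydrogen on an oxygen on an aromatic ring. Going by the values given here, no measured pair isolates this change. Among the compounds with values here, the only guide is compound 1, which carries methoxy and no hydroxy and still gives 193000 nM in this assay. On that basis no shift beyond the scatter is expected, perhaps a slight drift towards a higher number. The expected change is a 1.4-fold higher number from compound 2 to compound 3 (0.15 log units; within the scatter). For compound 3 the estimated value is 150000 nM, with an expected range of 80000 nM to 280000 nM.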

Compound 3, concentration for total growth inhibition: 127000 nM
Compound 3: middle estimate off by 1.2-fold (0.07 log units), on the high side, and the stated range covers the measured number.
By their numbers in this assay, from the lowest: compounds 2, 3 and 1 (each within the scatter of the next).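

Taken alone, the change from hydroxy to methoxy on the aromatic ring now has a direct reading in this assay (a 1.2-fold higher number from compound 2 to compound 3 (0.07 log units; within the scatter)), so placing methyl on this oxygen produces no difference that can be told from the scatter. Going by these compounds alone, the second methoxy can also be read on its own for the first time: hydrogen in place of methoxy on an aromatic carbon (a 1.5-fold lower number from compound 1 to compound 3 (0.18 log units; within the scatter)) likewise stays within the scatter, and neither substitution at these places separates the compounds. No supporting measurement bears on these results.

Going by these compounds, whether a longer chain on this oxygen would give a step beyond the scatter remains open. The same is true of an amine or a carboxylic acid on the aromatic ring.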